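This account rests on a few compounds, and the source may have more. Where it says the series, first, only, none or still open, it means among the compounds named here.

Compound 1 `CC1CCC(Oc2cccc3ccc(N)nc23)C1`, compound 2 `CCOCC(C)Oc1cccc2ccc(N)nc12` and compound 3 `COCC(C)Oc1cccc2ccc(N)nc12` share one core and differ only in the group on an oxygen on an aromatic ring. In an assay on cells with melanin-concentrating hormone receptor 1 (Homo sapiens) as the target, read by radioligand binding (on this read-out higher numbers stand for weaker inhibition and lower numbers for stronger inhibition), compound 1 gives 823 nM, compound 2 gives 1070 nM and compound 3 gives 606 nM. Compound 3 carries the lowest of the three numbers, yet its steps to both others stay within the scatter. Compound 4 `CCC#CCOc1cccc2ccc(N)nc12` differs from compound 3 by pent-2-yn-1-yl in place of 1-(methoxymethyl)ethyl on an oxygen on an aromatic ring. For the measured compounds named here, the steps that bear on this change at the same oxygen are a 1.4-fold lower number from compound 1 to compound 3 (0.13 log units; within the scatter), a 1.3-fold higher number from compound 1 to compound 2 (0.11 log units; within the scatter) and a 1.8-fold lower number from compound 2 to compound 3 (0.25 log units; within the scatter), none beyond the scatter. Compound 4 is therefore expected to show a step of a 1.2-fold higher number from compound 3 to compound 4 (0.06 log units; within the scatter) in this assay. The value of compound 4 in this assay is estimated at 700 nM, with a range from 300 nM to 1700 nM.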

Compound 4, half-maximal inhibitory concentration: > 2000 nM
Compound 4 gave a limit, no number (the forecaster's own chance of this, stated with the estimate: 5%); at least 2.8-fold (0.45 log units) between middle value and limit.
By their numbers in this assay, from the lowest: compounds 3, 1 and 2 (each within the scatter of the next). At a limit, above all of these: compound 4.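

In this assay compound 4 reads only as a limit, not a number: the limit of > 2000 nM in this assay, at which 1 of the 4 values shown sits. For the compounds shown here, the earlier changes at this oxygen on an aromatic ring all stayed within the scatter, but pent-2-yn-1-yl is the first group to give a separation, in place of 1-(methoxymethyl)ethyl (an at least 3.3-fold higher number from compound 3 to compound 4 (0.51 log units; beyond the scatter)) and of 3-methylcyclopentyl (an at least 2.4-fold higher number from compound 1 to compound 4 (0.38 log units; beyond the scatter)). Against compound 2 the floor alone separates nothing yet (an at least 1.8-fold higher number from compound 2 to compound 4 (0.27 log units; that floor lies within the scatter)).

From the compounds shown here alone, how far past its limit compound 4 lies stays open. Going by these compounds, whether the triple bond carries the step also stays open, as does what a saturated pentyl chain or an amine on a chain at this oxygen would give.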